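The source may report more compounds than this note shows. Statements on the series, on what has been measured and on what is new or still open speak of the compounds shown alone.

Measured so far:
- compound 1, `C=CCO/N=C/c1c(N)ncnc1Oc1ccc2[nH]c(C)cc2c1F`: 40 nM in a functional assay on HCT-116 cells (Homo sapiens) for antiproliferative activity; a lower number here means a stronger inhibitor, a higher number a weaker inhibitor
- compound 2, `CO/N=C/c1c(N)ncnc1Oc1ccc2[nH]c(C)cc2c1`: 386 nM in this assay

For the measured compounds named here, compound 1 gives the lowest of the two numbers in this assay; compound 2 sits well beyond the scatter from it, at a clearly higher value, though the two differ in more than one place and no single step between them is drawn.

The next compound, compound 3, `COCCCO/N=C/c1c(N)ncnc1Oc1ccc2[nH]c(C)cc2c1F`, is to be measured in this assay. It differs from compound 1 by 2-methoxyethyl in place of vinyl on a saturated chain carbon bound to an oxygen on an unsaturated carbon, the chain growing by two heavy atoms and gaining one hydrogen-bond acceptor while the double bond outside the aromatic rings is lost. Going by the values given here, no measured pair shows a change of this kind, so the direction is open. The step from compound 1 to compound 3, a 1.4-fold higher number from compound 1 to compound 3 (0.14 log units; within the scatter), is expected to be small, not clearly beyond the scatter. Compound 3 is estimated at 55 nM, within 20 nM to 160 nM.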

Compound 3, half-maximal inhibitory concentration: 438 nM
Estimate against measurement, compound 3: 8.0-fold (0.90 log units) below; measured number outside the range, above it.
By their numbers in this assay, from the lowest: compound 1; then compounds 2 and 3 (each within the scatter of the next).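

Vinyl to 2-methoxyethyl on a saturated chain carbon bound to an oxygen on an unsaturated carbon is a large change in this assay (an 11-fold higher number from compound 1 to compound 3 (1.04 log units; beyond the scatter)). For the compounds shown here, this is the only single-place step, and it shows that this position does not tolerate every chain equally: with the core of compound 1 held fixed, the chain alone moves the number well beyond the scatter. Nothing measured on these compounds bears on the reason for this rise.

The step changes chain length, adds a hydrogen-bond acceptor and removes the double bond all at once, so the compounds shown leave open which of these matters. From the compounds shown here alone, a plain propyl or butyl chain in the same place would be needed to separate them, and whether an amine at the chain end behaves like the methoxy group also remains open.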